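Working notes: aryl swap and nitrogen acetylation in a small set

The source may hold more compounds than are shown below. What is called first, only, known or untested is meant among the compounds shown, and "the series" means these compounds.

Compound 1 `COc1ccc(-c2c(-c3cc(OC)c(OC)c(OC)c3)noc2NC(C)=O)cc1OC` in a functional assay on A549 cells (Homo sapiens) for cytotoxicity, read by MTT assay, with a stated time of 48 h (a higher number here means a weaker inhibitor, a lower number a stronger inhibitor), gives 19800 nM. Compound 2 `COc1cc(-c2noc(NC(C)=O)c2-c2ccc(Cl)cc2)cc(OC)c1OC`, in which (4-chlorophenyl in place of 3,4-dimethoxyphenyl on an aromatic carbon), gives 25000 nM in this assay; a 1.3-fold higher number from compound 1 to compound 2 (0.10 log units; within the scatter). Compound 3 `COc1ccc(-c2c(-c3cc(OC)c(OC)c(OC)c3)noc2N(C(C)=O)C(C)=O)cc1OC` carries the other change, (acetyl in place of hydrogen on an amide-type nitrogen). For compound 3 the read-out in this assay is only a limit, > 50000 nM. The step reads an at least 2.5-fold higher number from compound 1 to compound 3 (0.40 log units; beyond the scatter), and the limit of > 50000 nM in this assay, at which 1 of the 3 values shown sits, shows where that value sits. Compound 4 `COc1cc(-c2noc(N(C(C)=O)C(C)=O)c2-c2ccc(Cl)cc2)cc(OC)c1OC` is not yet measured; relative to compound 3 it carries 4-chlorophenyl in place of 3,4-dimethoxyphenyl on an aromatic carbon. This is the same kind of change as from compound 1 to compound 2, but around the place the ring atom that bears an acetamido group (4 heavy atoms) in the earlier pair is the ring atom that bears a diacetylamino group (7 heavy atoms) here. Beside the earlier step, the step from compound 3 to compound 4 is expected to be about a step that the limit leaves unreadable from compound 3 to compound 4, resting on a 1.3-fold higher number from compound 1 to compound 2 (0.10 log units; within the scatter), which stayed within the scatter. Compound 4 is therefore expected at about 65000 nM in this assay, most likely again reported only as a limit.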

Compound 4, half-maximal inhibitory concentration: > 50000 nM
Compound 4: no number, only a limit; the forecaster's own chance of this, stated with the estimate: 85%; the middle value is on the limit's open side.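

Compound 4 gives > 50000 nM in this assay, and this value is a limit of the assay. On the core of compound 2, acetyl in place of hydrogen on the amide-type nitrogen gives an at least 2.0-fold higher number from compound 2 to compound 4 (0.30 log units; that floor lies within the scatter), while the step between the two limits cannot be read. The change can be followed onto the second core only as a floor, which does not show that it carries over beyond the scatter or at the same size: the same change on two cores in this assay, an at least 2.5-fold higher number (0.40 log units; beyond the scatter) from compound 1 to compound 3 and an at least 2.0-fold higher number (0.30 log units; that floor lies within the scatter) from compound 2 to compound 4; the limit leaves it open whether they differ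

The compounds shown leave open how the 4-chlorophenyl and 3,4-dimethoxyphenyl groups compare once the nitrogen carries two acetyl groups. They also leave open whether a free amine, or a longer acyl chain on that nitrogen, would give a value rather than a limit in this assay.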